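A few compounds are considered here, and "the series" means these few. Any claim that something is new, unique, unknown or untested is made for them only; others in the source may bear on it.

Compound 3 `CCCC[C@@H](O)C(=O)N1[C@@H]2C[C@@H]2C[C@H]1C(=O)NCc1cc(Cl)ccc1-n1cnnn1` is the reference point here. For the measured compounds named here, in an ADME assay on Caco-2 cells (Homo sapiens) for permeability, read by LC-MS, in the apical to basolateral direction, with a stated time of 60 min, at pH 6.5 (a higher number here means that the compound crosses the layer faster, a lower number that the compound crosses the layer more slowly), compound 3 gives 35 10^-6 cm/s, the highest of the three numbers measured so far. Its nearest neighbour is compound 1 `CC(C)(C)[C@@H](O)C(=O)N1[C@@H]2C[C@@H]2C[C@H]1C(=O)NCc1cc(Cl)ccc1-n1cnnn1`, which in this assay gives 34 10^-6 cm/s, a separation that lies within the scatter, so no order between the two is claimed. Compound 2 `CC(C)(C)[C@@H](O)C(=O)N1C[C@@H]2C[C@@H]2[C@H]1C(=O)NCc1cc(Cl)ccc1-n1cnnn1`, with the ring fused on the other side of the shared core, gives 17 10^-6 cm/s in this assay, lower than compound 3 by a margin beyond the scatter.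

Going by the values given here, the one measured step at the side chain is a 1.0-fold higher number from compound 1 to compound 3 (0.01 log units; within the scatter); reshaping the chain there left the number unchanged.

Compound 4 `O=C(NCc1cc(Cl)ccc1-n1cnnn1)[C@@H]1C[C@H]2C[C@H]2N1C(=O)[C@H](O)CC1CC1`, not yet measured, differs from compound 3 by cyclopropyl in place of propyl on a saturated chain carbon, two bonds along the chain from a carbonyl carbon and an oxygen on a saturated carbon. Among the compounds with values here, only the step from compound 1 to compound 3 bears on this change, and it was flat. The expectation for compound 4 is therefore no step beyond the scatter, a 1.1-fold lower number from compound 3 to compound 4 (0.03 log units; within the scatter). Compound 4 is estimated at 33 10^-6 cm/s, within 20 10^-6 cm/s to 52 10^-6 cm/s.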

Compound 4, apparent permeability: 6.9 10^-6 cm/s
Compound 4: middle estimate off by 4.8-fold (0.68 log units), on the high side; measured number outside the range, below it.
By their numbers in this assay, from the lowest: compound 4; then compounds 2, 1 and 3 (each within the scatter of the next, the first and the last beyond it).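

In this assay this side chain is not flat: cyclopropyl in place of propyl, with the same count of heavy atoms, gives a 5.1-fold lower number from compound 3 to compound 4 (0.71 log units; beyond the scatter) and a step beyond the scatter. Cyclopropylmethyl in place of tert-butyl gives a step of similar reach, a 4.9-fold lower number from compound 1 to compound 4 (0.69 log units; beyond the scatter) and this contrasts with butyl in place of tert-butyl, which gave a 1.0-fold higher number from compound 1 to compound 3 (0.01 log units; within the scatter) and stayed within the scatter, so among the groups shown the side chain carrying the ring stands apart from both open chains. No measurement at hand accounts for this drop.

Open, from the compounds shown here alone, is whether a larger ring in the same place, such as cyclobutyl or cyclopentyl, follows cyclopropyl or the open chains. Also open is whether the cyclopropyl drop carries over to the core of compound 2, shown here only with tert-butyl.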